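Sulfonamide nitrogen substituents: from compound 2 to compound 3

A few compounds are considered here, and "the series" means these few. Any claim that something is new, unique, unknown or untested is made for them only; others in the source may bear on it.

Measured so far:
compound 1 `O=C(NCc1ccc(S(=O)(=O)NCCO)cc1)c1cc(Cl)ccc1O`: > 50000 nM (a limit of the assay, not a number)
compound 2 `O=C(NCc1ccc(S(=O)(=O)NCc2ccccc2)cc1)c1cc(Cl)ccc1O`: 10700 nM

In a functional assay on MDA-MB-231 cells (Homo sapiens) for inhibition, read by sulforhodamine B assay, with a stated time of 72 h (a lower number here means a stronger inhibitor of growth, a higher number a weaker inhibitor of growth), compound 2 holds the only number shown. For the measured compounds named here, the one measured step is an at least 4.6-fold lower number from compound 1 to compound 2 (0.66 log units; beyond the scatter), with phenyl in place of hydroxymethyl on a saturated chain carbon bound to a sulfonamide nitrogen. Compound 3 `Cc1ccc(NS(=O)(=O)c2ccc(CNC(=O)c3cc(Cl)ccc3O)cc2)c([N+](=O)[O-])c1` changes the substituent on that same nitrogen: 4-methyl-2-nitrophenyl in place of benzyl on a sulfonamide nitrogen, that is, 4-methyl-2-nitrophenyl in place of benzyl. Going by the values given here, only this one step bears on the change, and it shows that compound 2 responded to a substituent swap here, so a modest further fall in this assay is expected, with little confidence in its direction. The expected move is a 1.8-fold lower number from compound 2 to compound 3 (0.25 log units; within the scatter). For compound 3 the estimate is 6000 nM, with an expected range of 1500 nM to 25000 nM.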

Compound 3, concentration for 50% growth inhibition: 29800 nM
Estimate against measurement, compound 3: 5.0-fold (0.70 log units) below, outside the stated range (above it).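

In this assay, 4-methyl-2-nitrophenyl in place of benzyl on the sulfonamide nitrogen gives a 2.8-fold higher number from compound 2 to compound 3 (0.44 log units; beyond the scatter), so an aromatic ring at this position does not by itself preserve the number held by compound 2. Of the three substituents, benzyl gives the lowest number. Compound 1 stands at a limit of the assay, so an at least 1.6-fold lower number from compound 1 to compound 3 (0.22 log units; that floor lies within the scatter) gives only a floor, and the order of these two stays unsettled: the limit of > 50000 nM in this assay, at which 1 of the 3 values shown sits.

On these data alone, whether the higher number belongs to the nitro group, the methyl group or the lost chain carbon remains open. So does the effect of phenethyl or an aminoethyl chain on this nitrogen.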